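Methylsulfonyl for methoxy on the benzylamine of compound 1

The compounds below may be only part of what the source reports. "The series", "measured", "known", "first", "only" and "open" are said of these compounds alone.

Measured compounds:
compound 1 `COc1ccccc1CNc1ncnn1-c1cccc(Cl)c1Cl`: 57.5 nM
compound 2 `COc1ccc(CNc2ncnn2-c2cccc(Cl)c2Cl)cc1`: 1620 nM

Two compounds share a core and differ in where a methoxy group sits on the benzyl ring. In a functional assay for antagonist activity at P2X purinoceptor 7 (Homo sapiens), read by FLIPR and calcium flux (on this read-out lower numbers stand for stronger inhibition and higher numbers for weaker inhibition), compound 1 gives 57.5 nM and stands at the lowest number of the two. Compound 2 gives 1620 nM in this assay, a gap that lies beyond the scatter, so the two values are clearly apart.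

Compound 3 `CS(=O)(=O)c1ccccc1CNc1ncnn1-c1cccc(Cl)c1Cl` is not yet measured. It comes from compound 1 by one exchange: methylsulfonyl in place of methoxy on an aromatic carbon. For the measured compounds named here, no measured pair shows what such an exchange does on this core, so the expectation rests on compound 1 alone. The step from compound 1 to compound 3 is expected to be modest and toward a higher number, a 2.6-fold higher number from compound 1 to compound 3 (0.42 log units; beyond the scatter). Compound 3 is thus estimated at 150 nM in this assay, within a range from 40 nM to 600 nM.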

Compound 3, half-maximal inhibitory concentration: 20 nM
The estimate for compound 3 lay 7.5-fold (0.88 log units) above the measured number, outside the stated range (below it).
By their numbers in this assay, from the lowest: compound 3; then compound 1; then compound 2.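

In this assay the exchange of methoxy for methylsulfonyl on this aromatic carbon gives a 2.9-fold lower number from compound 1 to compound 3 (0.46 log units; beyond the scatter) and so counts as a modest step beyond the scatter. The position therefore holds a group of 4 heavy atoms in place of one of 2 without any loss, and the methoxy group of compound 1 is not required there for a low number. Nothing shown accounts for the direction of this step.

From the compounds shown here alone, it remains open whether methylsulfonyl would give a similar result at the ring position where compound 2 carries its methoxy group. Also open, going by these compounds, is what a sulfonamide, a carboxylic acid or an amine would do on the same aromatic carbon, and whether a longer chain such as ethylsulfonyl would be accepted there.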